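This account rests on a few compounds, and the source may have more. Where it says the series, first, only, none or still open, it means among the compounds named here.

Compound 1 `COc1ccc(-c2cc(/C=C/C(=O)c3ccc(N)cc3)[nH]n2)cc1`: -96%
Compound 2 `COc1ccc(-c2cc(/C=C/C(=O)c3ccc(N)cc3)[nH]n2)cc1OC`: -98%
Compound 3 `COc1cc(C(=O)/C=C/c2cc(-c3cc(OC)c(OC)c(OC)c3)n[nH]2)cc(OC)c1OC`: -98%

All three numbers come from a functional assay on A498 cells (Homo sapiens) for cytotoxicity, read by sulforhodamine B assay, with a stated time of 48 h, tested at 100 uM; a lower number here means a stronger effect, a higher number a weaker effect of the compound at the concentration tested. Compound 2 and compound 1 differ in one place, (hydrogen in place of methoxy on an aromatic carbon), and this change made a step of a number 2 percentage points higher from compound 2 to compound 1 (within the scatter). Compound 3 shares the level of compound 2 at the digits printed; how the core of compound 3 differs from the core of compound 2 is not broken down here.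

Compound 4 `COc1ccc(-c2cc(/C=C/C(=O)c3cc(OC)c(OC)c(OC)c3)[nH]n2)cc1OC` has not yet been measured in this assay. It differs from compound 3 by hydrogen in place of methoxy on an aromatic carbon. Among the measured compounds shown here, this is the same kind of change as the one from compound 2 to compound 1, but not the same: in compound 3 the site is also meta to a methoxy group, while in compound 2 it is not. The expected step is a number 2 percentage points higher from compound 3 to compound 4 (within the scatter), and this expectation rests on the earlier step of a number 2 percentage points higher from compound 2 to compound 1 (within the scatter), which stayed within the scatter. Compound 4 is therefore estimated at -96%, with a range from -100% to -85%.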

Compound 4, a percentage reported as activity, at one concentration (the size of the read-out at that concentration, not a potency): -91%
Compound 4: the middle estimate sits 5 percentage points below what was measured, and the stated range covers the measured number.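

In this assay, putting hydrogen in place of methoxy on an aromatic carbon gave a number 7 percentage points higher from compound 3 to compound 4 (within the scatter). Set beside the earlier case, the change behaves alike on both cores, with no difference that can be told from the scatter: the same change on two cores in this assay, a number 2 percentage points higher (within the scatter) from compound 2 to compound 1 and a number 7 percentage points higher (within the scatter) from compound 3 to compound 4, 5 percentage points apart, within the scatter of two such steps This rests on only two pairs tested at one concentration, so it gives no potency and no rule for cores beyond these.

The compounds shown leave open what other groups at this place would do, such as a carboxylic acid or a longer chain like ethoxy.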